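The compounds below may be only part of what the source reports. "The series", "measured", "known", "first", "only" and "open" are said of these compounds alone.

In a functional assay on K562 cells (Homo sapiens) for cytotoxicity, read by MTT assay, with a stated time of 48 h (a higher number here means a weaker inhibitor, a lower number a stronger inhibitor), only one of the three measured compounds gives an actual number. Compound 1 `COc1cc([C@@H]2C[C@]2(CO)C(=O)Nc2ccccc2Cl)cc(OC)c1OC` reads 16900 nM. Compound 2 `COc1cc([C@@H]2C[C@]2(CO)C(=O)NCc2ccc(C)cc2)cc(OC)c1OC` gives only a limit of the assay, > 100000 nM. Compound 3 `COc1cc([C@H]2C[C@@]2(CO)C(=O)Nc2ccccc2)cc(OC)c1OC` also gives only a limit, > 100000 nM. All that is known of compound 2 is therefore (the limit of > 100000 nM in this assay, at which 2 of the 3 values shown sit).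

For the measured compounds named here, the one measured step, an at least 5.9-fold higher number from compound 1 to compound 2 (0.77 log units; beyond the scatter), concerns the group on the amide nitrogen, not configuration. Compound 4 `COc1cc([C@@H]2C[C@@]2(CO)C(=O)NCc2ccc(C)cc2)cc(OC)c1OC` keeps the 4-methylbenzyl group of compound 2, and the change is confined to configuration: the two compounds have the same atoms and bonds and differ only in configuration as drawn: 1 of 2 stereo elements differ; a stereocentre at a saturated ring carbon is drawn S in compound 2 and R in compound 4. Going by the values given here, no measured step isolates a change of this kind, so the size of the step is poorly constrained, and no clear shift in either direction is expected. The estimated change is a number no higher from compound 2 to compound 4 (the limit leaves the size open), and another result at the limit of the assay would not be surprising. Compound 4 is expected to read about 100000 nM, with an estimated range from 30000 nM to 200000 nM.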

Compound 4, half-maximal inhibitory concentration: > 100000 nM
Compound 4: a limit, no number (the forecaster's own chance of this, stated with the estimate: 65%); the middle value lies on the limit itself.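

Like compound 2, compound 4 gives only a limit of the assay, > 100000 nM, so no step can be read between these two compounds. The compounds shown leave open whether the configuration at this saturated ring carbon affects the reading in this assay at all.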